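A Bromo for Chloro Swap on the Shared Core

A few compounds are considered here, and "the series" means these few. Any claim that something is new, unique, unknown or untested is made for them only; others in the source may bear on it.

compound 1 `c1cn2cc(-c3ccsc3)nc(-c3ccc4ncn(C5CCCCC5)c4c3)c2n1`: 5.68%
compound 2 `CC(=O)c1ccc(-c2cn3ccnc3c(-c3ccc4ncn(C5CCCCC5)c4c3)n2)cc1`: 9.2%
compound 3 `Clc1ccc(-c2cn3ccnc3c(-c3ccc4ncn(C5CCCCC5)c4c3)n2)cc1`: 16.4%

Going by the values given here, in a functional assay on HT-29 cells (Homo sapiens) for inhibition, read by sulforhodamine B assay, with a stated time of 48 h, tested at 10 uM (a higher number here means more inhibition at the concentration tested (going by the name of the read-out), a lower number less inhibition), compound 3 gives the highest of the three numbers, though its gap to compound 2 lies within the scatter; only the step of a number 10.7 percentage points higher from compound 1 to compound 3 (beyond the scatter) is beyond it. Compound 4 `Brc1ccc(-c2cn3ccnc3c(-c3ccc4ncn(C5CCCCC5)c4c3)n2)cc1` differs from compound 3 by bromo in place of chloro on an aromatic carbon. Among the compounds with values here, the one measured step at this place, a number 7.2 percentage points higher from compound 2 to compound 3 (within the scatter), was within the scatter, and no step between two halogens has been measured here. Compound 4 is therefore expected to show no step beyond the scatter, a number 0.6 percentage points higher from compound 3 to compound 4 (within the scatter). Compound 4 is estimated at 17%, with a range from 5% to 30%.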

Compound 4, a percentage reported as inhibition, at one concentration (the size of the read-out at that concentration, not a potency): 20.9%
For compound 4 the middle estimate is 3.9 percentage points below the measured one; the measured number falls inside the stated range.
By their numbers in this assay, from the lowest: compounds 1, 2, 3 and 4 (each within the scatter of the next, the first and the last beyond it).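

In this assay, going by these compounds alone, the first step between two halogens at this place, a number 4.5 percentage points higher from compound 3 to compound 4 (within the scatter), leaves bromo and chloro indistinguishable. Bromo does separate from acetyl, a number 11.7 percentage points higher from compound 2 to compound 4 (beyond the scatter), which chloro did not, and the gap to the thiophen-3-yl compound widens to a number 15.2 percentage points higher from compound 1 to compound 4 (beyond the scatter). All of these read-outs remain single-concentration percentages, so they show no potency. As far as these compounds go, whether an amine or a carboxylic acid on this aromatic carbon would give a number like those of the halogens remains open. Nothing available explains why these steps take the sizes they do.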